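The compounds below may be only part of what the source reports. "The series", "measured", "known", "first", "only" and "open" are said of these compounds alone.

For the measured compounds named here, compound 1 `CNC(=O)C(N)CCSCCCCC(=O)O` is one of two compounds measured in an assay on isolated protein for inhibition of betaine--homocysteine S-methyltransferase 1 (Homo sapiens), with a stated time of 30 min, tested at 20 uM (a higher number here means more inhibition at the concentration tested (going by the name of the read-out), a lower number less inhibition), where compound 1 gives 8%. Compound 2 `NC(CCSCCCCC(=O)O)C(=O)N1CCCCC1` gives 9% in this assay. Going by the values given here, compound 1 holds the lowest of the two numbers, though the only measured step, a number 1 percentage points higher from compound 1 to compound 2 (within the scatter), lies within the scatter, so the two compounds cannot be told apart on these numbers. Compound 3 `N#CC(N)CCSCCCCC(=O)O` has not been measured in this assay. It differs from compound 1 by cyano in place of methylcarbamoyl on a saturated chain carbon bound to an amine nitrogen and a saturated chain carbon. Among the compounds with values here, the one measured step, a number 1 percentage points higher from compound 1 to compound 2 (within the scatter), changes a group on the same carbonyl carbon and stays within the scatter; no step in which the methylcarbamoyl group itself is replaced has been measured. On this footing no movement beyond the scatter is expected for compound 3, with a step of no change at the digits printed from compound 1 to compound 3 (within the scatter). Compound 3 is therefore estimated at 8%, with a range from 0% to 20%.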

Compound 3, a percentage reported as inhibition, at one concentration (the size of the read-out at that concentration, not a potency): 9%
Beside the measured number, compound 3's estimate is 1 percentage points below it, and the stated range covers the measured number.
By their numbers in this assay, from the lowest: compounds 1, 2 and 3 (each within the scatter of the next).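

Replacing the methylcarbamoyl group itself with cyano, on a saturated chain carbon bound to an amine nitrogen and a saturated chain carbon, gives a number 1 percentage points higher from compound 1 to compound 3 (within the scatter) in this assay. The earlier step only exchanged a group on the carbonyl carbon, whereas this one removes the whole methylcarbamoyl group, going from 4 heavy atoms to 2 and from 1 hydrogen-bond donor to 0, and the reading still does not move beyond the scatter. Nothing available accounts for this absence of a detectable change.

As far as these compounds go, with all the compounds this close together in this assay, it remains open whether any group at this position can move the reading beyond the scatter. From the compounds shown here alone, what a carboxylic acid or a primary amide would give on this carbon also remains open.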